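A few compounds are considered here, and "the series" means these few. Any claim that something is new, unique, unknown or untested is made for them only; others in the source may bear on it.

Three compounds have so far been measured in an assay on HEK293 cells for antagonist activity at P2X purinoceptor 7 (Homo sapiens), read by fluorescence, with a stated time of 2 h; on this read-out lower numbers stand for stronger inhibition and higher numbers for weaker inhibition:

Compound 1, `O=C(c1ccc(Cl)c(C(F)(F)F)c1)N1CCC(n2cncc2-c2ccc(OS(=O)(=O)c3cccc4cnccc34)cc2)CC1`: 45 nM
Compound 2, `O=C(c1ccc(Oc2ccccc2)cc1)N1CCC(n2cncc2-c2ccc(OS(=O)(=O)c3cccc4cnccc34)cc2)CC1`: 187 nM
Compound 3, `CS(=O)(=O)c1ccc(C(=O)N2CCC(n3cncc3-c3ccc(OS(=O)(=O)c4cccc5cnccc45)cc3)CC2)cc1`: 25 nM

All three share the same core and differ only in the aromatic group attached to the carbonyl. Compound 3 gives the lowest of the three numbers, but its separation from compound 1 is small: a 1.8-fold lower number from compound 1 to compound 3 (0.26 log units; within the scatter). The gap to compound 2 is larger: a 7.5-fold lower number from compound 2 to compound 3 (0.87 log units; beyond the scatter). So compound 3 and compound 1 cannot be told apart on these data, while compound 2 clearly sits at a weaker level.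

The next compound, compound 4, `O=C(c1ccc([N+](=O)[O-])cc1)N1CCC(n2cncc2-c2ccc(OS(=O)(=O)c3cccc4cnccc34)cc2)CC1`, keeps everything of compound 3 except one group: nitro in place of methylsulfonyl on an aromatic carbon. Both measured steps bear on this position. Swapping the group on that ring moved the number only a little when a chloro and trifluoromethyl pattern was replaced, and a modest amount when phenoxy was replaced. Nitro, like methylsulfonyl, is a small group with two hydrogen-bond acceptors and no donors, so no step beyond the scatter is expected here.

Compound 4 is therefore estimated to give 40 nM, within a range from 15 nM to 120 nM. The expected step, a 1.6-fold higher number from compound 3 to compound 4 (0.20 log units; within the scatter), is small.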

Compound 4, half-maximal inhibitory concentration: 1.49 nM
For compound 4 the middle estimate is 27-fold (1.43 log units) above the measured one; measured number below the stated range.
By their numbers in this assay, from the lowest: compound 4; then compounds 3 and 1 (each within the scatter of the next); then compound 2.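

In this assay, going by these compounds alone, the earlier steps could not show how much this single group matters, since compound 1 and compound 3 stayed within the scatter of each other despite their different ring substituents. Replacing methylsulfonyl with nitro gives a 17-fold lower number from compound 3 to compound 4 (1.22 log units; beyond the scatter) even though both groups are uncharged, with the same count of hydrogen-bond acceptors and no hydrogen-bond donors, so these shared counts do not predict the result here. Compound 4 also stands clear of the other two, with a 30-fold lower number from compound 1 to compound 4 (1.48 log units; beyond the scatter) and a 130-fold lower number from compound 2 to compound 4 (2.10 log units; beyond the scatter), which makes it the strongest of the four on this read-out, yet nothing measured here accounts for the size of these steps.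

Going by these compounds, it remains open whether a nitrile, a carboxylic acid or an amine on the same aromatic carbon would give a number close to that of compound 4 or close to that of compound 3. On these data alone, it is also open whether nitro would give a similarly large step if the shared core were changed elsewhere.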